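Swapping a ring-nitrogen substituent and what clearance may follow

The compounds below may be only part of what the source reports. "The series", "measured", "known", "first", "only" and "open" are said of these compounds alone.

Three compounds have been examined in an ADME assay on liver for metabolic stability, with Liver microsome (Rattus norvegicus) as the target, using microsomes and NADPH, with a stated time of 30 min, tested at 0.5 uM; a higher number here means faster removal of the compound, a lower number slower removal. Compound 1 `CN1CCN(CCOc2nn(-c3ccccc3F)c3ccc(F)cc23)C1=O` gives 7200 mL/min/kg, compound 2 `CC(C)(O)CC(=O)N1CC[C@H]2CN(c3cccc4c3cnn4-c3ccccc3F)C(=O)[C@H]21` gives 98.3 mL/min/kg, and compound 3 `CC(C)(C)OC(=O)N1CCN(c2cccc3c2cnn3-c2ccccc2F)C1=O` gives 120 mL/min/kg. Among these three numbers compound 3 stands second highest, but the gap to compound 2 is within the usual scatter of repeated measurements, so the two cannot be told apart on this evidence. Compound 1, by contrast, lies well above compound 3, beyond the scatter.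

Compound 4 `O=C1N(Cc2ncco2)CCN1c1cccc2c1cnn2-c1ccccc1F` has not yet been measured in this assay . It differs from compound 3 in one place: (1,3-oxazol-2-yl)methyl in place of tert-butoxycarbonyl on an amide-type nitrogen in a ring. Within the data shown here, no pair of measured compounds shows a change of this kind, so there is no comparable step from which to read off its effect, and the expectation below rests only on the numbers of compound 3 and its neighbours.

Given that, compound 4 is expected to give a number close to that of compound 3, with the step from one to the other likely to fall within the scatter or only slightly above it: the estimated step is a 1.3-fold higher number from compound 3 to compound 4 (0.10 log units; within the scatter). The estimated clearance for compound 4 is 150 mL/min/kg, with a range from 60 mL/min/kg to 400 mL/min/kg.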

Compound 4, clearance: 100 mL/min/kg
Beside the measured number, compound 4's estimate is 1.5-fold (0.18 log units) above it; measured number inside the range.
By their numbers in this assay, from the lowest: compounds 2, 4 and 3 (each within the scatter of the next); then compound 1.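

Among these compounds, this is the first comparison here between two compounds that differ in only one place, so the effect of a single change at this nitrogen can finally be read directly. In this assay, replacing tert-butoxycarbonyl, which has no ring, with (1,3-oxazol-2-yl)methyl, which carries one five-membered aromatic ring, gives a 1.2-fold lower number from compound 3 to compound 4 (0.08 log units; within the scatter), a step within the scatter, so the two compounds cannot be told apart and this exchange on the amide-type nitrogen has no readable effect on clearance. No accompanying measurement bears on why the clearance stays within the scatter across such a different pair of groups, so the result records an outcome without offering an explanation.

The compounds shown leave open whether this position would accept other groups just as readily, such as a carboxylic acid, an amine or a longer alkyl chain, since a single pair cannot show how far the result extends beyond these two groups. They also leave open whether the same exchange would give a similarly small step on a different core, as this step comes from one core only.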